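Benzyloxy in place of a sulfur-linked chlorophenyl

The source may hold more compounds than are shown below. What is called first, only, known or untested is meant among the compounds shown, and "the series" means these compounds.

Compound 1, `CCSc1cc(C)c(C(=O)N=C(N)N)cc1S(C)(=O)=O`: 5.9 nM
Compound 2, `Cc1cc(Sc2ccc(Cl)cc2)c(S(C)(=O)=O)cc1C(=O)N=C(N)N`: 19 nM

In a functional assay for inhibition of sodium/hydrogen exchanger (Oryctolagus cuniculus) (a higher number here means a weaker inhibitor, a lower number a stronger inhibitor), compound 1 gives 5.9 nM, and compound 2 gives 19 nM. Compound 2 stands highest of the two numbers measured; its nearest neighbour is compound 1, separated by a 3.2-fold higher number from compound 1 to compound 2 (0.51 log units; beyond the scatter). Compound 3, `Cc1cc(OCc2ccccc2)c(S(C)(=O)=O)cc1C(=O)N=C(N)N`, differs from compound 2 by benzyloxy in place of (4-chlorophenyl)sulfanyl on an aromatic carbon. Among the measured compounds shown here, only the step of a 3.2-fold higher number from compound 1 to compound 2 (0.51 log units; beyond the scatter) bears on this, and only loosely, since it exchanged an alkyl for an aryl group on a sulfur; no measured step compares an oxygen-linked with a sulfur-linked group. He therefore expects compound 3 to sit near compound 2, with a step of a 1.3-fold lower number from compound 2 to compound 3 (0.10 log units; within the scatter), and estimates 15 nM within a range from 5 nM to 50 nM.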

Compound 3, half-maximal inhibitory concentration: 28 nM
The estimate for compound 3 lay 1.9-fold (0.27 log units) below the measured number; the range from low to high includes it.
By their numbers in this assay, from the lowest: compound 1; then compounds 2 and 3 (each within the scatter of the next).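

Replacing (4-chlorophenyl)sulfanyl with benzyloxy, ortho to the methylsulfonyl group, gives a 1.5-fold higher number from compound 2 to compound 3 (0.17 log units; within the scatter) and so shows that an oxygen-linked group with a benzyl chain can stand at this position without a change beyond the scatter. Set against the ethylsulfanyl group, benzyloxy gives a 4.7-fold higher number from compound 1 to compound 3 (0.68 log units; beyond the scatter) and so, like the 4-chlorophenyl group, leaves a higher number than compound 1 gives. Nothing measured here accounts for these numbers.

On these data alone, the step from compound 2 to compound 3 changes the linking atom, the chain and the chlorine together, so their separate shares remain open. As far as these compounds go, whether ethoxy would match ethylsulfanyl, or an amine would be tolerated here, also remains open.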